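Shifting a fluorine from compound 3 to compound 4

The compounds below may be only part of what the source reports. "The series", "measured", "known", "first", "only" and "open" are said of these compounds alone.

compound 1 `COc1ccc(CN2CCC(CCNC(=O)/C=C/c3cc(C(C)(C)C)c(O)c(C(C)(C)C)c3)CC2)cc1` – 61200 nM
compound 2 `Cc1ccccc1CN1CCC(CCNC(=O)/C=C/c2cc(C(C)(C)C)c(O)c(C(C)(C)C)c2)CC1` – 65300 nM
compound 3 `CC(C)(C)c1cc(/C=C/C(=O)NCCC2CCN(Cc3ccc(F)cc3F)CC2)cc(C(C)(C)C)c1O` – 62400 nM

In a functional assay, read by spectrophotometry, with a stated time of 30 min (a lower number here means a stronger inhibitor, a higher number a weaker inhibitor), compound 3 gives 62400 nM and stands level with the other two compounds, since all three numbers lie within the usual scatter of one another. Compound 4 `CC(C)(C)c1cc(/C=C/C(=O)NCCC2CCN(Cc3ccc(F)c(F)c3)CC2)cc(C(C)(C)C)c1O` has the same atoms as compound 3, joined differently: 3,4-difluorophenyl in place of 2,4-difluorophenyl on a saturated chain carbon bound to an amine nitrogen in a ring and so 3,4-difluorophenyl takes the place of 2,4-difluorophenyl on a saturated chain carbon bound to an amine nitrogen in a ring.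

Three measured steps at this same place bear on the change: a 1.1-fold higher number from compound 1 to compound 2 (0.03 log units; within the scatter) and a 1.0-fold higher number from compound 1 to compound 3 (0.01 log units; within the scatter) and a 1.0-fold lower number from compound 2 to compound 3 (0.02 log units; within the scatter) and each of them stays within the scatter. None of them tests 3,4-difluorophenyl itself, so what follows is only an expectation. No step beyond the scatter and no particular direction is expected in this assay and the estimated step is a 1.0-fold lower number from compound 3 to compound 4 (0.00 log units; within the scatter) at most a small one. For compound 4 the estimated value is 62000 nM with an expected range from 35000 nM to 110000 nM still to be put to the test.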

Compound 4, half-maximal inhibitory concentration: 65700 nM
Estimate against measurement, compound 4: 1.1-fold (0.03 log units) below; the range from low to high includes it.
By their numbers in this assay, from the lowest: compounds 1, 3, 2 and 4 (each within the scatter of the next).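

In this assay, going from 2,4-difluorobenzyl to 3,4-difluorobenzyl gives a 1.1-fold higher number from compound 3 to compound 4 (0.02 log units; within the scatter), so rearranging the same two fluorines on this group leaves the reading level. The earlier steps shown here exchanged one set of atoms for another, whereas this one keeps the atoms and alters only how they are joined. The new group also stands level with the other two, with a 1.0-fold higher number from compound 2 to compound 4 (0.00 log units; within the scatter) and a 1.1-fold higher number from compound 1 to compound 4 (0.03 log units; within the scatter), making all four groups at this place alike here, and no measurement at hand accounts for this sameness.

As far as these compounds go, all four groups are substituted phenyl rings, so it remains open whether a plain phenyl, a pyridine or a phenyl bearing a carboxylic acid would shift the number at this place. From the compounds shown here alone, whether the same flat reading would hold with a longer chain elsewhere in the shared core also remains open.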